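Replacing 4-chlorophenyl with methyl in compound 3

The compounds below may be only part of what the source reports. "The series", "measured", "known", "first", "only" and "open" are said of these compounds alone.

In a functional assay on the whole organism for inhibition, with Felis catus as the target, with a stated time of 30 min (a higher number here means that more compound is needed for the effect, a lower number that less compound is needed), compound 1 `Cc1ccccc1OCCNCC(O)COc1ccccc1` gives 0.031 mg/kg, compound 2 `OC(CNCCOc1cccc(Cl)c1)COc1ccccc1` gives 0.375 mg/kg and compound 3 `OC(CNCCOc1ccc(Cl)cc1)COc1ccccc1` gives 0.08 mg/kg. That leaves compound 3 in the middle of the three, with the second highest number. Compound 4 `COCCNCC(O)COc1ccccc1` has not been measured yet, and it differs from compound 3 by one change: methyl in place of 4-chlorophenyl on an oxygen on a saturated carbon. The measured steps bear on this change only indirectly, since each swaps one substituted phenyl for another at that same place. They still show that the number responds to what sits there: a 12-fold higher number from compound 1 to compound 2 (1.08 log units; beyond the scatter), a 2.6-fold higher number from compound 1 to compound 3 (0.41 log units; beyond the scatter) and a 4.7-fold lower number from compound 2 to compound 3 (0.67 log units; beyond the scatter). For the measured compounds named here, no measured compound lacks the phenyl ring at this place, so the size of the coming step is uncertain. Removing the whole ring is a bigger structural change than any of those swaps, so a large step toward a higher number is expected, similar to the largest one seen. The expected step is a 13-fold higher number from compound 3 to compound 4 (1.10 log units; beyond the scatter). For compound 4 the estimated value is 1 mg/kg, with an expected range of 0.2 mg/kg to 5 mg/kg.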

Compound 4, dose for half-maximal effect: 0.13 mg/kg
Compound 4: the middle estimate sits 7.7-fold (0.89 log units) above what was measured, and the stated range ends above it.
By their numbers in this assay, from the lowest: compound 1; then compounds 3 and 4 (each within the scatter of the next); then compound 2.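

In this assay the ring at this place turns out not to be required: with methyl on the oxygen, one heavy atom instead of seven, there is a 1.6-fold higher number from compound 3 to compound 4 (0.21 log units; within the scatter) and so no real loss against the 4-chlorophenyl compound. The other two steps point in opposite directions, with a 2.9-fold lower number from compound 2 to compound 4 (0.46 log units; beyond the scatter) and then a 4.2-fold higher number from compound 1 to compound 4 (0.62 log units; beyond the scatter) showing that a ring here can give a lower or a higher number than methyl, depending on the ring's substituent. Nothing available explains these differences.

The compounds shown leave open how a longer chain such as propyl or an unsubstituted phenyl would behave on this oxygen. They also do not show whether an amine at the end of such a chain would change the number.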